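The source may report more compounds than this note shows. Statements on the series, on what has been measured and on what is new or still open speak of the compounds shown alone.

Working notes on the series in a functional assay on T47D cells (Homo sapiens) for cytotoxicity, read by sulforhodamine B assay, with a stated time of 48 h; a lower number here means that less compound is tolerated, a higher number that more compound is tolerated.

Compound 1 `ClCc1ccccc1Cn1cnc2c(Cl)nc(Cl)nc21` carries a dichlorinated core with a benzyl group bearing a chloromethyl arm. In this assay compound 1 gives only a limit, > 100000 nM, and no number. Compound 2 `ClCc1cccc(Cn2cnc3c(Cl)nc(Cl)nc32)c1` moves the chloromethyl arm to another position on the benzyl ring; compound 2 also reaches only the limit of this assay at > 100000 nM. Compound 3 `ClCc1cccc(Cn2cnc3nc(Cl)nc(Cl)c32)c1` attaches the same benzyl group at the other nitrogen of the shared core; compound 3 likewise stops at the limit, > 100000 nM. So compound 1 stands where every measured member of the set stands: the limit of > 100000 nM in this assay, at which 3 of the 3 values shown sit. Among the measured compounds shown here, no two measured compounds differ in a single place, so no measured step is available and the scatter of this assay cannot be compared against any real change.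

Compound 4 `Nc1nc(Cl)c2ncn(Cc3ccccc3CCl)c2n1` has not yet been measured. It differs from compound 1 by amino in place of chloro on an aromatic carbon. For the measured compounds named here, with no measured step to lean on, the expectation for the move from compound 1 to compound 4 is no change beyond the scatter, a number no higher from compound 1 to compound 4 (the limit leaves the size open). For compound 4 the estimate in this assay is 100000 nM, within 30000 nM to 300000 nM, with the likeliest outcome being that only a limit is reported again.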

Compound 4, concentration lethal to 50% of the cells: > 100000 nM
Compound 4: a limit, no number (the forecaster's own chance of this, stated with the estimate: 70%); the middle value sits exactly at the limit.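

In this assay compound 4 gives only a limit, > 100000 nM. The step from compound 1 to compound 4 cannot be read, because both compounds stand at the same limit: the limit of > 100000 nM in this assay, at which 4 of the 4 values shown sit.

The compounds shown leave open whether any of these structures gives a number in this assay, and so what a change in one place does to it.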